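Working notes: lipophilicity across three compounds and one candidate

A few compounds are considered here, and "the series" means these few. Any claim that something is new, unique, unknown or untested is made for them only; others in the source may bear on it.

Measured so far:
compound 1, `CCO/C(O)=C1\C(C)=NC(C)=C(C(=O)OC)C1c1cccc(C(F)(F)F)c1`, 3.9
compound 2, `CCOC(=O)C1=C(C)NC(C)=C(C(=O)OCC)C1c1cccc(O)c1`, 4.03
compound 3, `CCOC(=O)C1=C(C)N=C(C)/C(=C(/O)OCC)C1c1ccc(I)cc1`, 4.7

In a physicochemical assay for lipophilicity (on this read-out lower numbers stand for lower lipophilicity and higher numbers for higher lipophilicity), compound 3 gives 4.7, the highest of the three numbers; compound 2 stands nearest and compound 1 furthest, both lower by more than the scatter. Among the measured compounds shown here, no pair of measured compounds differs in a single place, so no measured step exists in this set.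

Compound 4, `CCOC(=O)C1=C(C)N=C(C)/C(=C(/O)OCC)C1c1cccc(OC)c1`, is the next candidate. Its change from compound 3: 3-methoxyphenyl in place of 4-iodophenyl on a saturated ring carbon

For the measured compounds named here, no measured step shows this change. The expectation for this assay is a drop beyond the scatter, with a number 1.00 log units lower from compound 3 to compound 4 (beyond the scatter) as the estimated step. Compound 4 is estimated at 3.7, within a range from 3.2 to 4.2.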

Compound 4, partition coefficient: 3.22
Estimate against measurement, compound 4: 0.48 log units above, and the stated range covers the measured number.
By their numbers in this assay, from the lowest: compound 4; then compounds 1 and 2 (each within the scatter of the next); then compound 3.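

In this assay, among the compounds shown here, 3-methoxyphenyl in place of 4-iodophenyl on the saturated ring carbon gives a number 1.48 log units lower from compound 3 to compound 4 (beyond the scatter), the first step that isolates a single place. The read-out therefore responds strongly to what this ring carbon carries, at least for this pair. Nothing available bears on why the number moves.

Still open, from the compounds shown here alone, is how much of the step belongs to the substituent and how much to its place on the phenyl ring, since both change at once. Also open, going by these compounds, is how a 4-methoxyphenyl or an aminophenyl group would read at this ring carbon.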